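Replacing the piperazine group of compound 3

The source may hold more compounds than are shown below. What is called first, only, known or untested is meant among the compounds shown, and "the series" means these compounds.

In an ADME assay on microsomes from liver (Mus musculus) for metabolic stability, read by LC-MS, with a stated time of 10 min (on this read-out lower numbers stand for a less stable compound and higher numbers for a more stable compound), compound 3 `C[C@@H]1CN(c2cccc3c2C[C@H](CN(C)[C@H]2CCCc4cccnc42)NC3)C[C@H](C)N1` gives 85.6% and compound 1 `c1cnc2c(c1)CCC[C@@H]2N(CC1CC1)C[C@H]1Cc2c(cccc2N2CCNCC2)CN1` gives 88.3% with the two lying within the scatter of each other. Compound 2 `CN(C[C@H]1Cc2c(cccc2N2CCN(C3COC3)CC2)CN1)[C@H]1CCCc2cccnc21` gives 50.8% and so stands well under both of them.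

Compound 4 `CN(C[C@H]1Cc2c(cccc2N2CCN(C3CC3)CC2)CN1)[C@H]1CCCc2cccnc21` differs from compound 3 in one place, on an aromatic carbon of the shared core: 4-cyclopropylpiperazin-1-yl in place of 3,5-dimethylpiperazin-1-yl on an aromatic carbon is the whole of the change. Within the data shown here, no measured compound carries the 4-cyclopropylpiperazin-1-yl group, so the step has no direct precedent.

Among the measured compounds shown here, the one measured step that bears on it is a number 34.8 percentage points higher from compound 2 to compound 3 (beyond the scatter) and it is large. The entering group resembles the 4-(oxetan-3-yl)piperazin-1-yl of compound 2 in bearing a small ring on the piperazine, although a single step establishes no pattern. Compound 4 is therefore expected to fall back part of the way towards compound 2 at 50.8% without necessarily reaching it, since oxetane and cyclopropyl are different rings. The expected move is a number 23.6 percentage points lower from compound 3 to compound 4 (beyond the scatter) on this estimate, a drop of moderate to large size. For compound 4 the estimated value is 62% with an expected range from 42% to 80% in this assay.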

Compound 4, percent of the compound remaining: 7%
Estimate against measurement, compound 4: 55 percentage points above; measured number outside the range, below it.
By their numbers in this assay, from the lowest: compound 4; then compound 2; then compounds 3 and 1 (each within the scatter of the next).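

In this assay, among these compounds, this position on the aromatic carbon proves far more sensitive than the earlier compounds could show: the change to 4-cyclopropylpiperazin-1-yl gives a number 78.6 percentage points lower from compound 3 to compound 4 (beyond the scatter) and leaves compound 4 the lowest of the series, clearly under compound 2. Small rings on the piperazine nitrogen are not interchangeable either, as cyclopropyl in place of oxetan-3-yl alone gives a number 43.8 percentage points lower from compound 2 to compound 4 (beyond the scatter) even though both compounds carry a small ring there, so the identity of the ring matters and not merely its presence. Nothing available explains why compound 4 stands so low.

The step from compound 3 to compound 4 removes the two methyl groups on the piperazine ring and adds the cyclopropyl on its nitrogen in a single move, and the compounds shown do not separate these two parts of the change. Also open, as far as these compounds go, is how a plain methyl or an isopropyl group on that nitrogen would read in this assay, or a morpholine in place of the piperazine, and whether either would stand nearer to compound 3 or to compound 4.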